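Swapping bromo for 4-methoxybenzyl on the shared core

A few compounds are considered here, and "the series" means these few. Any claim that something is new, unique, unknown or untested is made for them only; others in the source may bear on it.

Compound 1, `COc1cc(Cn2cc(COc3cccc(/C=C4\C(=O)Nc5ccccc54)c3)nn2)cc(OC)c1`: "not determined" (no result reported). Compound 2, `O=C1Nc2ccc(Br)cc2/C1=C/c1cccc(OCc2cn(Cc3ccccc3)nn2)c1`: 35100 nM.

Within the data shown here, in a functional assay on DU-145 cells (Homo sapiens) for inhibition, read by MTT assay, with a stated time of 48 h (a higher number here means a weaker inhibitor, a lower number a stronger inhibitor), compound 2 gives 35100 nM, the only number recorded; compound 1 carries no value. Compound 3, `COc1ccc(Cc2ccc3c(c2)/C(=C/c2cccc(OCc4cn(Cc5ccccc5)nn4)c2)C(=O)N3)cc1`, is yet to be measured. It differs from compound 2 in one place: 4-methoxybenzyl in place of bromo on an aromatic carbon. Among the measured compounds shown here, no measured pair of this kind exists, so the size and direction of the step are uncertain. In this assay the estimated step is a 1.8-fold lower number from compound 2 to compound 3 (0.24 log units; within the scatter). Compound 3 is estimated at 20000 nM, from 5000 nM to 80000 nM.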

Compound 3, half-maximal inhibitory concentration: 6700 nM
Estimate against measurement, compound 3: 3.0-fold (0.47 log units) above; the measured number falls inside the stated range.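

In this assay, putting 4-methoxybenzyl in place of bromo on this aromatic carbon gives a 5.2-fold lower number from compound 2 to compound 3 (0.72 log units; beyond the scatter), a step beyond the usual scatter. The position therefore accepts a group with its own six-membered aromatic ring, and the inhibitor becomes stronger. This rests on a single pair, and nothing measured here explains the step.

As far as these compounds go, what remains open is whether the methoxy group or the benzyl part carries the change. From the compounds shown here alone, it is also open whether an amine, a carboxylic acid or a longer alkyl chain on this carbon would shift the number in the same direction.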